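This account rests on a few compounds, and the source may have more. Where it says the series, first, only, none or still open, it means among the compounds named here.

Of the compounds shown here, two with the same core have been measured so far in an ADME assay on the whole organism (Rattus norvegicus) for pharmacokinetics, at a dose of 1 mg/kg by the intravenous route; a higher number here means that more of the compound sits outside the plasma, a lower number that more of the compound stays in the plasma. Compound 1 `N#Cc1cnc(N2CCC(C(=O)N3N=CC[C@H]3c3cc(F)cc(F)c3)CC2)cn1` gives 6.1 L/kg, and compound 2 `Cc1nnc(N2CCC(C(=O)N3N=CC[C@H]3c3cc(F)cc(F)c3)CC2)o1` gives 1.3 L/kg, the lower of the two numbers. The next compound, compound 3 `N#Cc1cc(N2CCC(C(=O)N3N=CC[C@H]3c3cc(F)cc(F)c3)CC2)ncn1`, keeps that core and differs from compound 2 only on an amine nitrogen in a ring: a group of 8 heavy atoms (5 carbon, 3 nitrogen; one six-membered aromatic ring with 2 hetero atoms) in place of a group of 6 heavy atoms (3 carbon, 2 nitrogen, 1 oxygen; one five-membered aromatic ring with 3 hetero atoms), on an amine nitrogen in a ring.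

Among the compounds with values here, one measured step bears on this change. Swapping 5-cyanopyrazin-2-yl for 5-methyl-1,3,4-oxadiazol-2-yl at that nitrogen gave a 4.7-fold lower number from compound 1 to compound 2 (0.67 log units; beyond the scatter). The group entering compound 3 is not 5-cyanopyrazin-2-yl, but it too is a six-membered aromatic ring with 2 hetero atoms that carries a nitrile. Because compound 1 gives 6.1 L/kg with such a group, a move back up is likely, though a single step is thin evidence and probably not all of it returns. The expected change is a 3.5-fold higher number from compound 2 to compound 3 (0.54 log units; beyond the scatter). For compound 3, the estimated value in this assay is 4.5 L/kg, with an expected range of 2.2 L/kg to 9 L/kg.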

Compound 3, volume of distribution at steady state: 4.6 L/kg
Compound 3: middle estimate off by 1.0-fold (0.01 log units), on the low side, and the stated range covers the measured number.
By their numbers in this assay, from the lowest: compound 2; then compounds 3 and 1 (each within the scatter of the next).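

In this assay a second six-membered aromatic ring carrying a nitrile, attached at the same amine nitrogen, behaves like the first (a 1.3-fold lower number from compound 1 to compound 3 (0.12 log units; within the scatter)), so compound 1 and compound 3 cannot be told apart even though the atoms of their rings are arranged differently. Within the data shown here, the gap to 5-methyl-1,3,4-oxadiazol-2-yl (a 3.5-fold higher number from compound 2 to compound 3 (0.55 log units; beyond the scatter)) therefore no longer rests on a single group: both nitrile-bearing six-membered rings stand well above compound 2, and within this small set no compound goes against that. Nothing shown here explains the difference between these groups.

From the compounds shown here alone, the nitrile and the six-membered aromatic ring enter together, so it remains open which of the two goes with the higher number, and the same six-membered ring with a methyl in place of the nitrile, or a five-membered aromatic ring with a nitrile, would separate them. Going by these compounds, it is also open where the number would fall with an amine or a carboxylic acid on the ring at this nitrogen.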